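This account rests on a few compounds, and the source may have more. Where it says the series, first, only, none or still open, it means among the compounds named here.

Compound 1, `CC1=CC[C@H](C(C)(C)NC(=S)N/N=C/c2ccccc2)CC1`, gives 71400 nM in a functional assay on U-251 cells (Homo sapiens) for inhibition, read by sulforhodamine B assay, with a stated time of 48 h; on this read-out higher numbers stand for weaker inhibition of growth and lower numbers for stronger inhibition of growth.
Compound 2, `CC1=CC[C@H](C(C)(C)NC(=S)N/N=C/c2ccc(O)cc2)CC1`, reaches only the limit of this assay, > 100000 nM.
Compound 3, `CC1=CC[C@H](C(C)(C)NC(=S)N/N=C/c2ccc(Cl)cc2)CC1`, also reaches only the limit of this assay, > 100000 nM.

On the numbers shown, compound 2 stands at the limit of this assay rather than at a measured number, the limit named in the limit of > 100000 nM in this assay, at which 2 of the 3 values shown sit. The step of an at least 1.4-fold higher number from compound 1 to compound 2 (0.14 log units; that floor lies within the scatter) and the step of an at least 1.4-fold higher number from compound 1 to compound 3 (0.14 log units; that floor lies within the scatter) are both read only against that limit, and the step that the two limits leave unreadable from compound 2 to compound 3 cannot be read at all. Compound 4, `COc1cc(/C=N/NC(=S)NC(C)(C)[C@H]2CC=C(C)CC2)ccc1O`, is not yet measured in this assay; it differs from compound 2 by methoxy in place of hydrogen on an aromatic carbon. Within the data shown here, no measured step adds a methoxy group, so the only guide is the limit at which compound 2 sits and the small changes seen from compound 1 on the same ring. The expected step is therefore a step that the limit leaves unreadable from compound 2 to compound 4, that is, nothing beyond the scatter. For compound 4 the estimate is 120000 nM, with a range from 40000 nM to 300000 nM, and it is expected that this assay will again report only a limit.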

Compound 4, concentration for total growth inhibition: 32600 nM
Estimate against measurement, compound 4: 3.7-fold (0.57 log units) above, and the stated range ends above it.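

In this assay, methoxy on an aromatic carbon ortho to a hydroxy group gives an at least 3.0-fold lower number from compound 2 to compound 4 (0.48 log units; beyond the scatter), so a change at this position of the ring can move the read-out beyond the scatter, towards stronger inhibition of growth. The earlier ring changes could not show this: their floors lie within the scatter, and the step between the two compounds held at the limit cannot be read. The real size of the new step may be larger, because compound 2 has only a limit and not a measured number: the limit of > 100000 nM in this assay, at which 2 of the 4 values shown sit.

On these data alone, it remains open whether methoxy would give such a step without the hydroxy group on the ring. As far as these compounds go, it is also open whether ethoxy, a longer chain, or an amine at this position would do the same.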